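Replacing 4-bromophenyl on a cytotoxic amide series

The compounds below may be only part of what the source reports. "The series", "measured", "known", "first", "only" and "open" are said of these compounds alone.

Compound 1 `Cc1ccc(F)cc1NC(=O)CN1CCN(c2nnc(Cc3ccccc3)c3ccccc23)CC1`: "not active" (no number reported)
Compound 2 `O=C(CN1CCN(c2nnc(Cc3ccccc3)c3ccccc23)CC1)Nc1ccc(Br)cc1`: 2000 nM

Of the compounds shown here, two sharing one core have been tested in a functional assay on A549 cells (Homo sapiens) for cytotoxicity, read by MTT assay, with a stated time of 72 h; a higher number here means a weaker inhibitor, a lower number a stronger inhibitor. Among the measured compounds shown here, compound 2 gives 2000 nM, and this is the only number available, so it cannot yet be ranked against a second value. Compound 1 is reported as "not active" (no number reported), with no number attached.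

The next compound to be tested is compound 3 `Cc1ccc(NC(=O)CN2CCN(c3nnc(Cc4ccccc4)c4ccccc34)CC2)c(C)c1`, which keeps the shared core and alters only the aromatic group on the amide-type nitrogen. Relative to compound 2, the change is 2,4-dimethylphenyl in place of 4-bromophenyl on an amide-type nitrogen. In words, 2,4-dimethylphenyl stands in place of 4-bromophenyl.

The evidence for predicting the outcome in this assay is thin. Compound 1, which also carries a methyl group on the aromatic ring at this nitrogen, reads "not active" (no number reported), and that single case leans the expectation toward weaker inhibition. The expected change, a moderate loss, is a 2.5-fold higher number from compound 2 to compound 3 (0.40 log units; beyond the scatter). A result within the usual scatter of compound 2 would not be surprising, and neither would a report with no number. For compound 3 the estimated value is 5000 nM, with an expected range of 1500 nM to 20000 nM.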

Compound 3, half-maximal inhibitory concentration: "not active" (no number reported)
Compound 3: no number reported; the estimate stays without a comparison.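

In this assay, among the compounds shown here, compound 3 reads "not active" (no number reported) and so, like compound 1, offers no number to set against compound 2, leaving no step to read from compound 2 to compound 3. Nothing measured here bears on this result. The compounds shown leave open which aromatic groups on the amide-type nitrogen, other than 4-bromophenyl, give a number at all.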